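The compounds below may be only part of what the source reports. "The series", "measured", "known", "first", "only" and "open" are said of these compounds alone.

Compound 1 `O=C(NS(=O)(=O)c1ccc(F)cc1)c1ccc(Nc2nc(NC3(c4ccc(Cl)cc4)CC3)nc(OCC(F)(F)F)n2)cc1`: 100%
Compound 2 `CC(C)C(=O)NCCS(=O)(=O)NC(=O)c1ccc(Nc2nc(NC3(c4ccc(Cl)cc4)CC3)nc(OCC(F)(F)F)n2)cc1`: 86%

These two compounds share one core and differ only in the group on a sulfonyl sulfur. In an ADME assay on microsomes from liver (Homo sapiens) for metabolic stability, with a stated time of 10 min (a higher number here means that more of the compound is left, a lower number that less of the compound is left), compound 1 gives 100%, the highest of the two numbers shown. The step of a number 14 percentage points lower from compound 1 to compound 2 (beyond the scatter) lies beyond the scatter. Compound 3 `CC(C)NC(=O)NCCS(=O)(=O)NC(=O)c1ccc(Nc2nc(NC3(c4ccc(Cl)cc4)CC3)nc(OCC(F)(F)F)n2)cc1` has not yet been measured. It differs from compound 1 in one place: 2-((isopropylcarbamoyl)amino)ethyl in place of 4-fluorophenyl on a sulfonyl sulfur. Within the data shown here, the one measured step that bears on this change is the step from compound 1 to compound 2, in which a 2-((isopropylcarbonyl)amino)ethyl also replaced the 4-fluorophenyl on the sulfonyl sulfur and the number fell modestly. A modest drop of similar size is therefore expected for compound 3, a number 15 percentage points lower from compound 1 to compound 3 (beyond the scatter). For compound 3 the estimate in this assay is 85%, with a range from 70% to 100%.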

Compound 3, percent of the compound remaining: 100%
Compound 3: middle estimate off by 15 percentage points, on the low side; low and high end bracket the measured number.
By their numbers in this assay, from the lowest: compound 2; then compounds 1 and 3 (each within the scatter of the next).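

In this assay, the 2-((isopropylcarbamoyl)amino)ethyl group on the sulfonyl sulfur gives no change at the digits printed from compound 1 to compound 3 (within the scatter), so the lower number of compound 2 does not follow simply from 4-fluorophenyl giving way to a chain with no ring. Within the chain, isopropylamino in place of isopropyl on a carbonyl carbon gives a number 14 percentage points higher from compound 2 to compound 3 (beyond the scatter), which ties the difference to that single change at the end of the chain. Nothing available explains this difference.

The compounds shown leave open whether the number in this assay holds for a longer chain on the sulfonyl sulfur, or for a chain ending in a carboxylic acid or a primary amine. They also do not show how a cyclopropylamino or tert-butylamino group would compare with isopropylamino on that carbonyl carbon.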